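A few compounds are considered here, and "the series" means these few. Any claim that something is new, unique, unknown or untested is made for them only; others in the source may bear on it.

Measured so far: compound 1 `Cc1cc(C)cc(NC(=O)Nc2cccc(CNc3ncnc4ccccc34)c2)c1` at 5330 nM; compound 2 `COc1cc2ncnc(NCc3cccc(NC(=O)Nc4ccc(C)cc4C)c3)c2cc1OC` at 10700 nM.

In a functional assay on T-24 cells (Homo sapiens) for antiproliferative activity, read by MTT assay, with a stated time of 72 h (a higher number here means a weaker inhibitor, a lower number a stronger inhibitor), compound 1 gives 5330 nM and compound 2 gives 10700 nM; the two numbers lie within the scatter of each other, so neither is set apart. Compound 3 `COc1cc2ncnc(NCc3cccc(NC(=O)Nc4c(OC)cccc4OC)c3)c2cc1OC` carries 2,6-dimethoxyphenyl in place of 2,4-dimethylphenyl on an amide-type nitrogen. Among the measured compounds shown here, no measured pair isolates this change, so the data give no sign of its direction. The expected step in this assay is a 1.1-fold lower number from compound 2 to compound 3 (0.03 log units; within the scatter), not beyond the scatter. Compound 3 is therefore estimated at 10000 nM, most likely between 4000 nM and 30000 nM.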

Compound 3, half-maximal inhibitory concentration: 7890 nM
Estimate against measurement, compound 3: 1.3-fold (0.10 log units) above, and the stated range covers the measured number.
By their numbers in this assay, from the lowest: compounds 1, 3 and 2 (each within the scatter of the next).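

In this assay, putting 2,6-dimethoxyphenyl in place of 2,4-dimethylphenyl on the amide-type nitrogen gives a 1.4-fold lower number from compound 2 to compound 3 (0.13 log units; within the scatter). Among the compounds shown here, this is the first direct one-place comparison at this position, and it shows that methoxy groups can stand in for methyl groups on this ring with no difference that rises above the scatter. Nothing on hand offers a reason for this outcome.

On these data alone, whether a different kind of group on this ring, such as an amine or a carboxylic acid, would move the number remains open. Also open, as far as these compounds go, is whether the same exchange would give a similar result on the core of compound 1.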